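Swapping hydrogen for fluoro on the benzylidene ring

The source may report more compounds than this note shows. Statements on the series, on what has been measured and on what is new or still open speak of the compounds shown alone.

Of the compounds shown here, three sharing one core have been tested in an ADME assay on HEL cells (Homo sapiens) for cytotoxicity; on this read-out lower numbers stand for higher toxicity in this test and higher numbers for lower toxicity in this test. Compound 3 `O=C(COc1cccc2ccccc12)N/N=C/c1ccccc1` gives 64.5 ug/mL, the highest number of the three, although compound 1 `O=C(COc1cccc2ccccc12)N/N=C/c1ccc(O)cc1` with 60.6 ug/mL lies within the scatter of it. Compound 2 `O=C(COc1cccc2ccccc12)N/N=C/c1ccccc1O` gives 3.57 ug/mL, and the step of an 18-fold higher number from compound 2 to compound 3 (1.26 log units; beyond the scatter) is large. The next compound, compound 4 `O=C(COc1cccc2ccccc12)N/N=C/c1ccc(F)cc1`, differs from compound 3 by fluoro in place of hydrogen on an aromatic carbon; cut one bond further out, the change reads phenyl to 4-fluorophenyl. Among the measured compounds shown here, only one measured step touches the same place on the ring: the step of a 1.1-fold higher number from compound 1 to compound 3 (0.03 log units; within the scatter) removed a hydroxy from the 4-position and left the number essentially unchanged. The large step of a 17-fold lower number from compound 1 to compound 2 (1.23 log units; beyond the scatter) concerns a different place and does not bear on this change. For the measured compounds named here, with only one step at the relevant place, and that within the scatter, the expected step of a 1.1-fold lower number from compound 3 to compound 4 (0.03 log units; within the scatter) is none beyond the scatter. Compound 4 is therefore estimated at 60 ug/mL, between 30 ug/mL and 120 ug/mL, in this assay.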

Compound 4, half-maximal cytotoxic concentration: 71.6 ug/mL
The estimate for compound 4 lay 1.2-fold (0.08 log units) below the measured number; the measured number falls inside the stated range.
By their numbers in this assay, from the lowest: compound 2; then compounds 1, 3 and 4 (each within the scatter of the next).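

In this assay, placing fluoro on the aromatic carbon para to a large group gives a 1.1-fold higher number from compound 3 to compound 4 (0.05 log units; within the scatter) and so adds a third group to this position with no step beyond the scatter. Replacing the hydroxy of compound 1 with fluoro gives a 1.2-fold higher number from compound 1 to compound 4 (0.07 log units; within the scatter), so hydrogen, hydroxy and fluoro all read alike here among these compounds. Compound 2 remains the one that stands apart, with its 2-hydroxyphenyl changed to 4-fluorophenyl giving a 20-fold higher number from compound 2 to compound 4 (1.30 log units; beyond the scatter) (large). No measurement is available to explain this pattern. Open, on these data alone, is whether an amine, a carboxylic acid or a longer chain at the same position would also leave the number within the scatter. Also open, as far as these compounds go, is whether the low number of compound 2 is specific to hydroxy or would appear with another group, such as an amine, at that place on the ring.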